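Saturating the Vinyl Group: Compound 3 to Compound 4

This account rests on a few compounds, and the source may have more. Where it says the series, first, only, none or still open, it means among the compounds named here.

The series shares one core carrying three benzyl ethers and a free hydroxy group. Compound 1 `CCCC[C@@H]1O[C@H](COCc2ccccc2)[C@@H](OCc2ccccc2)[C@H](OCc2ccccc2)[C@H]1O` is reported in a functional assay on HL-60 cells (Homo sapiens) for antiproliferative activity, read by MTT assay (on this read-out higher numbers stand for weaker inhibition and lower numbers for stronger inhibition), as "not active" (no number reported). Compound 2 `O[C@@H]1[C@@H](OCc2ccccc2)[C@H](OCc2ccccc2)[C@@H](COCc2ccccc2)O[C@H]1CC1CCCCC1` gives 4100 nM, and compound 3 `C=C[C@@H]1O[C@H](COCc2ccccc2)[C@@H](OCc2ccccc2)[C@H](OCc2ccccc2)[C@H]1O` gives 11800 nM, the higher of the two numbers, reached by a 2.9-fold higher number from compound 2 to compound 3 (0.46 log units; beyond the scatter). Compound 4 `CC[C@@H]1O[C@H](COCc2ccccc2)[C@@H](OCc2ccccc2)[C@H](OCc2ccccc2)[C@H]1O` differs from compound 3 by ethyl in place of vinyl on a saturated ring carbon. Within the data shown here, no measured step swaps vinyl for ethyl; the only step available exchanges a larger saturated group, and compound 1 with butyl lacks a number altogether. Compound 4 is therefore expected to stay close to compound 3, with a 1.4-fold higher number from compound 3 to compound 4 (0.13 log units; within the scatter) possibly drifting toward weaker inhibition, estimated at 16000 nM within 7000 nM to 40000 nM.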

Compound 4, half-maximal inhibitory concentration: 8200 nM
Estimate against measurement, compound 4: 2.0-fold (0.29 log units) above; the measured number falls inside the stated range.
By their numbers in this assay, from the lowest: compounds 2, 4 and 3 (each within the scatter of the next, the first and the last beyond it).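

In this assay, ethyl in place of vinyl gives a 1.4-fold lower number from compound 3 to compound 4 (0.16 log units; within the scatter), so losing the double bond at this ring carbon leaves the number within the scatter. The step from the larger group reads a 2.0-fold higher number from compound 2 to compound 4 (0.30 log units; within the scatter), which places compound 4 within the scatter of both compound 2 and compound 3, although those two lie beyond the scatter of each other. No evidence is available to explain these steps.

It remains open why compound 1, with butyl, is reported as "not active" (no number reported) while ethyl gives a number. Going by these compounds, how an amine or a carboxylic acid at this ring carbon would read is also open.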